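The source may report more compounds than this note shows. Statements on the series, on what has been measured and on what is new or still open speak of the compounds shown alone.

In a functional assay on SH-SY5Y cells (Homo sapiens) for cytotoxicity, read by MTT assay, with stated times of 24 h and 4 h (a higher number here means that more compound is needed for the effect, a lower number that less compound is needed), compound 1 `COc1ccc(/C=C/C(=O)NCc2ccc(OCc3nc(C)c(C)nc3C)c(OC)c2)cc1O` gives 8560 nM. Compound 2 `COc1cc(CNC(=O)/C=C/c2ccc(OC)c(OCc3nc(C)c(C)nc3C)c2)ccc1OCc1nc(C)c(C)nc1C` carries (3,5,6-trimethylpyrazin-2-yl)methyl in place of hydrogen on an oxygen on an aromatic ring and gives 11600 nM; the step is a 1.4-fold higher number from compound 1 to compound 2 (0.13 log units; within the scatter). Compound 3 `COc1cc(CNC(=O)/C=C/c2cc(OC)c(OC)cc2OC)ccc1O` gives 2410 nM, the lowest of the three values, and its core differs from that of compound 1 by more than a single counted change, so the difference between the two cores is not broken down here.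

Compound 4 `COc1cc(OC)c(OC)cc1/C=C/C(=O)NCc1ccc(OCc2nc(C)c(C)nc2C)c(OC)c1` has not yet been measured in this assay. It differs from compound 3 by (3,5,6-trimethylpyrazin-2-yl)methyl in place of hydrogen on an oxygen on an aromatic ring, the same change that turned compound 1 into compound 2, at a place described in the same words. Because the earlier step of a 1.4-fold higher number from compound 1 to compound 2 (0.13 log units; within the scatter) stayed within the scatter, the step from compound 3 to compound 4 is expected to be small as well, estimated as a 1.3-fold higher number from compound 3 to compound 4 (0.12 log units; within the scatter). Going by the values given here, on that basis compound 4 is estimated at 3200 nM, with a likely range from 1600 nM to 7000 nM, resting on the single precedent of compound 1 and compound 2.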

Compound 4, half-maximal effective concentration: 3620 nM
The estimate for compound 4 lay 1.1-fold (0.05 log units) below the measured number; low and high end bracket the measured number.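

In this assay, putting (3,5,6-trimethylpyrazin-2-yl)methyl in place of hydrogen on an oxygen on an aromatic ring gave a small step on both cores, and the two steps agree: the same change on two cores in this assay, a 1.4-fold higher number (0.13 log units; within the scatter) from compound 1 to compound 2 and a 1.5-fold higher number (0.18 log units; within the scatter) from compound 3 to compound 4, 1.1-fold (0.04 log units) apart, within the scatter of two such steps. On the newer core this is a 1.5-fold higher number from compound 3 to compound 4 (0.18 log units; within the scatter), so the change carried over between these two cores without a clear shift in the number, whereas 2,4,5-trimethoxyphenyl in place of 3-hydroxy-4-methoxyphenyl gives a 2.4-fold lower number from compound 1 to compound 4 (0.37 log units; beyond the scatter). Two cores in one assay do not show that the step would stay this small on a further core, and they do not explain why it is small.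

The compounds shown leave open whether other groups on that oxygen, such as a chain ending in an amine or a carboxylic acid, would also give a small step. They also leave open how the change would behave on a core carrying a different aromatic group, such as a fluorophenyl.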